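This account rests on a few compounds, and the source may have more. Where it says the series, first, only, none or still open, it means among the compounds named here.

Measured so far in a functional assay on Bel-7402 cells (Homo sapiens) for antiproliferative activity, read by MTT assay, with a stated time of 72 h (a higher number here means a weaker inhibitor, a lower number a stronger inhibitor), for the shared core:
- Compound 1 (`C=C1C(=O)O[C@H]2[C@H]1CC/C(Cn1cc(Cn3cc(F)c(=O)[nH]c3=O)nn1)=C\CC[C@@]1(C)O[C@@H]21`) gives > 20000 nM as a limit of the assay, not a number.
- Compound 2 (`C=C1C(=O)O[C@H]2[C@H]1CC/C(COC(=O)CCC(=O)N1CCN(C(=O)Cn3cc(F)c(=O)[nH]c3=O)CC1)=C\CC[C@@]1(C)O[C@@H]21`) gives > 20000 nM as a limit of the assay, not a number.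
- Compound 3 (`C=C1C(=O)O[C@H]2[C@H]1CC/C(COC(=O)Cn1cc(F)c(=O)n(Cc3ccc([N+](=O)[O-])cc3)c1=O)=C\CC[C@@]1(C)O[C@@H]21`) gives 4070 nM as a measured number.

Within the data shown here, compound 3 is the only member with a number, and that number is 4070 nM in this series. Compound 1 and compound 2 sit at the limit of > 20000 nM in this assay, at which 2 of the 3 values shown sit, and offer no number for comparison.

Compound 4 (`C=C1C(=O)O[C@H]2[C@H]1CC/C(COC(=O)Cn1cc(F)c(=O)n(Cc3cc(F)ccc3F)c1=O)=C\CC[C@@]1(C)O[C@@H]21`) keeps the rest of compound 3 and changes one group: 2,5-difluorophenyl in place of 4-nitrophenyl on a saturated chain carbon bound to an aromatic nitrogen with 2,5-difluorophenyl in place of 4-nitrophenyl on a saturated chain carbon bound to an aromatic nitrogen. Among the measured compounds shown here, no measured pair covers this exchange, so the only numerical anchor is compound 3 at 4070 nM in the series. The expected change in this assay is modest and towards weaker inhibition, an estimated 1.5-fold higher number from compound 3 to compound 4 (0.17 log units; within the scatter) that may not clear the usual scatter. For compound 4 the estimated value is 6000 nM with an expected range of 2000 nM to 18000 nM in the same read-out.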

Compound 4, half-maximal inhibitory concentration: 3060 nM
Compound 4: the middle estimate sits 2.0-fold (0.29 log units) above what was measured, and the stated range covers the measured number.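

In this assay, among these compounds, the exchange of 4-nitrobenzyl for 2,5-difluorobenzyl gives the only readable step at this place, a 1.3-fold lower number from compound 3 to compound 4 (0.12 log units; within the scatter), so the two compounds cannot be ordered. The 4-nitrophenyl group, with its hydrogen-bond acceptors, can give way to 2,5-difluorophenyl, which has none, without a step beyond the scatter, so a nitro group is not needed for a measured number at this place. Compound 1 and compound 2 carry limits rather than numbers, and steps to them cannot be read: the limit of > 20000 nM in this assay, at which 2 of the 4 values shown sit.

Going by these compounds, whether an unsubstituted benzyl, a 4-aminobenzyl or a benzyl bearing a carboxylic acid would move the number beyond the scatter remains open. Also open, on these data alone, is the effect of a longer chain between the aromatic nitrogen and the phenyl ring.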